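From Bromine to Methyl: Expecting Only a Small Shift

The source may report more compounds than this note shows. Statements on the series, on what has been measured and on what is new or still open speak of the compounds shown alone.

Among the two compounds measured in an assay on isolated protein for inhibition of Amine oxidase [flavin-containing] A (Homo sapiens), read by fluorescence, with a stated time of 15 min (on this read-out lower numbers stand for stronger inhibition and higher numbers for weaker inhibition), compound 2 `COc1ccc(/C=C/c2cc(OC)cc(OC)c2/C=C/C(=O)c2cc3ccc(Br)cc3oc2=O)cc1` stands lowest, giving 3010 nM. For the measured compounds named here, compound 1 `CCOc1ccc2cc(C(=O)/C=C/c3c(/C=C/c4ccc(OC)cc4)cc(OC)cc3OC)c(=O)oc2c1` gives 7070 nM, and the only step on record is a 2.3-fold lower number from compound 1 to compound 2 (0.37 log units; beyond the scatter). Compound 3 `COc1ccc(/C=C/c2cc(OC)cc(OC)c2/C=C/C(=O)c2cc3cc(C)ccc3oc2=O)cc1` differs from compound 2 by a group of 12 heavy atoms (10 carbon, 2 oxygen; one six-membered aromatic ring of carbon only, one six-membered aromatic ring with 1 hetero atom) in place of a group of 12 heavy atoms (9 carbon, 2 oxygen, 1 bromine; one six-membered aromatic ring of carbon only, one six-membered aromatic ring with 1 hetero atom), on a carbonyl carbon. Going by the values given here, that single step is the only guide, and it shows a change at this position moving the number only modestly. A similar change is therefore expected to shift the number little, if at all beyond the scatter, and the expected step is a 1.5-fold higher number from compound 2 to compound 3 (0.17 log units; within the scatter). Compound 3 is estimated at 4500 nM, between 2000 nM and 10000 nM.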

Compound 3, half-maximal inhibitory concentration: 30400 nM
Compound 3: the middle estimate sits 6.8-fold (0.83 log units) below what was measured, and the stated range ends below it.
By their numbers in this assay, from the lowest: compound 2; then compound 1; then compound 3.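

The step of a 10-fold higher number from compound 2 to compound 3 (1.00 log units; beyond the scatter) shows that in this assay this position can move the number much further than the earlier step of a 2.3-fold lower number from compound 1 to compound 2 (0.37 log units; beyond the scatter) suggested. Exchanging the bromine-bearing group for a carbon-and-oxygen group with the same heavy-atom count and the same rings is therefore far from a neutral swap on this carbonyl carbon. Nothing available explains this result.

Still open, from the compounds shown here alone, is whether the loss follows from losing the bromine alone. Going by these compounds, how a chlorine, a nitrile or an amine would read in its place also remains unknown.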